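Swapping the amide aryl group in a dibromophenyl thiadiazole series

The source may hold more compounds than are shown below. What is called first, only, known or untested is meant among the compounds shown, and "the series" means these compounds.

Measured compounds:
Compound 1 `Cc1cccc(NC(=O)CSc2snnc2-c2ccc(Br)cc2Br)c1C`: 241000 nM
Compound 2 `O=C(CSc1snnc1-c1ccc(Br)cc1Br)Nc1ccccn1`: 42400 nM
Compound 3 `Cc1ccc2sc(NC(=O)CSc3snnc3-c3ccc(Br)cc3Br)nc2c1`: 23600 nM

In an ADME assay on MT4 cells (Homo sapiens) for cytotoxicity, read by MTT assay, with a stated time of 5 days (a lower number here means that less compound is tolerated, a higher number that more compound is tolerated), compound 2 gives the second highest of the three numbers. Its nearest neighbour is compound 3, whose value lies within the usual scatter of that of compound 2, so no order between the two can be claimed. For the measured compounds named here, compound 1 stands apart: the step of a 5.7-fold lower number from compound 1 to compound 2 (0.75 log units; beyond the scatter) is beyond the scatter and is the only single-point change among the measured compounds.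

Compound 4 `Cc1ccc(NC(=O)CSc2snnc2-c2ccc(Br)cc2Br)cc1` has not yet been measured. It differs from compound 2 in one place: 4-methylphenyl in place of pyridin-2-yl on an amide-type nitrogen. Going by the values given here, only the step from compound 1 to compound 2 bears on this change, since it too exchanges a carbon-only aromatic ring for pyridin-2-yl on the same amide-type nitrogen, and it gave a modest lowering of the number. Going the other way, from pyridin-2-yl back to a methyl-bearing carbon-only ring, a rise of comparable size is therefore expected, though 4-methylphenyl is not 2,3-dimethylphenyl and the match is loose. For compound 4 the expected value in this assay is 150000 nM, with a range of 50000 nM to 400000 nM, corresponding to an estimated step of a 3.5-fold higher number from compound 2 to compound 4 (0.55 log units; beyond the scatter).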

Compound 4, half-maximal cytotoxic concentration: 24000 nM
Beside the measured number, compound 4's estimate is 6.3-fold (0.80 log units) above it, and the stated range ends above it.
By their numbers in this assay, from the lowest: compounds 3, 4 and 2 (each within the scatter of the next); then compound 1.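

In this assay, a 1.8-fold lower number from compound 2 to compound 4 (0.25 log units; within the scatter), so at this amide-type nitrogen the exchange of pyridin-2-yl for 4-methylphenyl gives no difference that can be read, and a carbon-only ring does not by itself bring back a high number. The other new step, a 10-fold lower number from compound 1 to compound 4 (1.00 log units; beyond the scatter), lies beyond the scatter and joins two carbon-only rings, so among these compounds the high number of compound 1 goes with 2,3-dimethylphenyl in particular and not simply with the absence of a ring nitrogen, which the earlier step from compound 1 to compound 2 could not separate. No supporting measurement accompanies these values. The data shown offer no explanation for the standing of 2,3-dimethylphenyl.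

The compounds shown leave open whether the number of methyl groups on the ring or their placement goes with this difference, and an unsubstituted phenyl ring would be the natural reference for both. They also leave open how a ring carrying a methoxy group, an amino group or a carboxylic acid would behave at the same amide-type nitrogen.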